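A few compounds are considered here, and "the series" means these few. Any claim that something is new, unique, unknown or untested is made for them only; others in the source may bear on it.

Compound 1 `S=C(Nc1ccccc1)N1N=C(c2ccc(Br)cc2)CC1c1ccc2c(c1)OCCO2` gives 870 nM in a functional assay on WM 266-4 cells (Homo sapiens) for antiproliferative activity, read by MTT assay, with a stated time of 48 h; a lower number here means a stronger inhibitor of growth, a higher number a weaker inhibitor of growth. Compound 2 `FC(F)(F)c1ccc(C2=NN(C(=S)Nc3ccccc3)C(c3ccc4c(c3)OCCO4)C2)cc1` gives 52400 nM in this assay.

Compound 2 stands with the higher number of the two, separated from compound 1 by a 60-fold higher number from compound 1 to compound 2 (1.78 log units; beyond the scatter). Compound 3 `S=C(Nc1ccccc1)N1N=C(c2ccccc2Br)CC1c1ccc2c(c1)OCCO2` differs from compound 2 in that (2-bromophenyl in place of 4-(trifluoromethyl)phenyl on a carbon with a double bond to nitrogen). Among the compounds with values here, the only measured step that bears on this is a 60-fold higher number from compound 1 to compound 2 (1.78 log units; beyond the scatter), a large rise when trifluoromethyl replaced bromo; here bromo returns, though within a 2-bromophenyl rather than the 4-bromophenyl of compound 1, which no measured step covers. A large fall in this assay is therefore expected, a 17-fold lower number from compound 2 to compound 3 (1.24 log units; beyond the scatter), but not a full return. Compound 3 is estimated at 3000 nM, within 400 nM to 25000 nM.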

Compound 3, concentration for 50% growth inhibition: > 200000 nM
Compound 3: no number, only a limit; the forecaster's own chance of this, stated with the estimate: 5%; middle value at least 66-fold (1.82 log units) from the limit.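

At this carbon with a double bond to nitrogen, bromo alone does not secure growth inhibition in this assay: 2-bromophenyl in place of 4-bromophenyl gives an at least 220-fold higher number from compound 1 to compound 3 (2.36 log units; beyond the scatter), so where the bromo sits on the phenyl counts, not only that it is there. Even 4-(trifluoromethyl)phenyl, itself poor, does better than 2-bromophenyl, with an at least 3.8-fold higher number from compound 2 to compound 3 (0.58 log units; beyond the scatter). Compound 3 gives a limit and not a number, so both steps are minimum sizes: the limit of > 200000 nM in this assay, at which 1 of the 3 values shown sits.

The compounds shown leave open whether a chloro or a methoxy group in place of the bromo of compound 1 would keep the growth inhibition. They also leave open whether an amine on that phenyl would be tolerated.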